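Notes on the ester chain in the shared core

This account rests on a few compounds, and the source may have more. Where it says the series, first, only, none or still open, it means among the compounds named here.

Measured so far:
compound 1, `CCCOC(=O)c1ccc2[nH]c(NC(=O)OC)nc2c1`, in a functional assay on L1210 cells (Mus musculus) for inhibition (a higher number here means a weaker inhibitor, a lower number a stronger inhibitor), compound 1 gives 7400 nM.
compound 2, `COC(=O)Nc1nc2cc(C(=O)OCC3CC3)ccc2[nH]1`, in this assay compound 2 gives 6900 nM.
compound 3, `C=CCOC(=O)c1ccc2[nH]c(NC(=O)OC)nc2c1`, in this assay compound 3 gives > 10000 nM, which is a limit of the assay and not a number.

Compound 3 sits at the weak end of the numbers shown, at the limit of > 10000 nM in this assay, at which 1 of the 3 values shown sits. Compound 4 is `COC(=O)Nc1nc2cc(C(=O)OCCC(C)CC(C)(C)C)ccc2[nH]1`, and its difference from compound 3 is 2,4,4-trimethylpentyl in place of vinyl on a saturated chain carbon bound to an oxygen next to a carbonyl group. Every measured step in this set also changes the chain on a saturated chain carbon bound to an oxygen next to a carbonyl group: a 1.1-fold lower number from compound 1 to compound 2 (0.03 log units; within the scatter), an at least 1.3-fold higher number from compound 1 to compound 3 (0.13 log units; that floor lies within the scatter) and an at least 1.4-fold higher number from compound 2 to compound 3 (0.16 log units; that floor lies within the scatter), none of them beyond the scatter. The expectation for compound 4 is therefore no step beyond the scatter, a number no higher from compound 3 to compound 4 (the limit leaves the size open), with the caveat that compound 3 is only a limit. Compound 4 is estimated at 10000 nM in this assay, with a range from 4500 nM to 25000 nM, and a real chance that only a limit is reported again.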

Compound 4, half-maximal inhibitory concentration: 740 nM
The estimate for compound 4 lay 14-fold (1.13 log units) above the measured number, and the stated range ends above it.
By their numbers in this assay, from the lowest: compound 4; then compounds 2 and 1 (each within the scatter of the next). At a limit, above all of these: compound 3.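

For the compounds shown here, the ester chain on a saturated chain carbon bound to an oxygen next to a carbonyl group is not indifferent to change in this assay: 2,4,4-trimethylpentyl in place of cyclopropyl gives a 9.3-fold lower number from compound 2 to compound 4 (0.97 log units; beyond the scatter), and the matching comparison with compound 1 gives a 10-fold lower number from compound 1 to compound 4 (1.00 log units; beyond the scatter), the first steps in this set beyond the scatter. In place of vinyl, the same chain gives an at least 13-fold lower number from compound 3 to compound 4 (1.13 log units; beyond the scatter), a size that is only a floor. Compound 3 is a limit and not a number: the limit of > 10000 nM in this assay, at which 1 of the 4 values shown sits.

The compounds shown do not separate the branching of the 2,4,4-trimethylpentyl chain from its length, a question an unbranched octyl chain would address. As far as these compounds go, how an amine or a carboxylic acid at the end of such a chain would read in this assay also stays open.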